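A few compounds are considered here, and "the series" means these few. Any claim that something is new, unique, unknown or untested is made for them only; others in the source may bear on it.

Working notes on the series.

Compound 2 `NC(=O)/C=C1\CCc2cc(Cl)ccc21` is the parent amide; in a functional assay on the whole organism with Rattus norvegicus as the target, at a dose of 20 mg/kg by the oral route (a lower number here means less inhibition, a higher number more inhibition at the dose given (going by the name of the read-out)), compound 2 gives 29%. Compound 1 `O=C(/C=C1\CCc2cc(Cl)ccc21)NC1CC1` carries the change cyclopropyl in place of hydrogen on an amide-type nitrogen on the same core. In this assay compound 1 gives 29%, and the step of no change at the digits printed from compound 2 to compound 1 (within the scatter) shows no effect of this change on the core of compound 2. Compound 3 `NC(=O)/C=C1\CCc2ccc(Br)cc21` has a different core; the difference between the two cores is not broken down here. In this assay compound 3 gives 21%, a value within the scatter of both compound 1 and compound 2. Compound 4 `O=C(/C=C1\CCc2ccc(Br)cc21)NC1CC1` is not yet measured and differs from compound 3 by cyclopropyl in place of hydrogen on an amide-type nitrogen, the same change as that from compound 2 to compound 1. Because the step of no change at the digits printed from compound 2 to compound 1 (within the scatter) was flat, the expected step of a number 1 percentage points higher from compound 3 to compound 4 (within the scatter) is also near zero. Compound 4 is therefore estimated at 22% in this assay, with a range from 8% to 36%.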

Compound 4, a percentage reported as inhibition, in the whole organism at one dose (the size of the read-out at that dose, not a potency): 4%
The estimate for compound 4 lay 18 percentage points above the measured number, outside the stated range (below it).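

In this assay, cyclopropyl in place of hydrogen on an amide-type nitrogen gives a number 17 percentage points lower from compound 3 to compound 4 (beyond the scatter), so the step seen on one core does not carry over to the other: the same change on two cores in this assay, no change at the digits printed (within the scatter) from compound 2 to compound 1 and a number 17 percentage points lower (beyond the scatter) from compound 3 to compound 4, 17 percentage points apart, beyond the scatter of two such steps

Within the data shown here, the flat step on the core of compound 2 is therefore no guide to the step on the core of compound 3. This rests on a single pair of steps at a single dose, and it does not show which feature of the two cores sets the steps apart or how the change would behave on a further core.

The compounds shown leave open whether an ethyl or a cyclopentyl group on the same nitrogen would follow cyclopropyl on each core. Also open, from the compounds shown here alone, is whether the two cores would part in the same way at another dose.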